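This account rests on a few compounds, and the source may have more. Where it says the series, first, only, none or still open, it means among the compounds named here.

Compound 1 `COc1ccc(C2=Nn3c(nnc3C(C)c3ccc(-c4ccccc4)c(F)c3)SC2)cc1`: 2600 nM
Compound 2 `CC(C)Cc1ccc(C(C)c2nnc3n2N=C(c2ccc(C(F)(F)F)cc2)CS3)cc1`: 4200 nM

In a functional assay on MCF7 cells (Homo sapiens) for inhibition, read by sulforhodamine B assay, with a stated time of 72 h (a lower number here means a stronger inhibitor, a higher number a weaker inhibitor), compound 2 stands at the higher of the two numbers, though its gap to compound 1 lies within the scatter, so the two are not truly told apart. Compound 3 `COc1ccc(C2=Nn3c(nnc3C(C)c3ccc(CC(C)C)cc3)SC2)cc1` differs from compound 2 by methoxy in place of trifluoromethyl on an aromatic carbon. For the measured compounds named here, no measured pair shows this exchange, so no firm guide exists. The expected step is a 1.4-fold lower number from compound 2 to compound 3 (0.15 log units; within the scatter), none beyond the scatter, since compound 1, which carries the same methoxy group, gives 2600 nM. Compound 3 is therefore estimated at 3000 nM, within a range from 1200 nM to 8000 nM.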

Compound 3, half-maximal inhibitory concentration: 5200 nM
For compound 3 the middle estimate is 1.7-fold (0.24 log units) below the measured one; low and high end bracket the measured number.
By their numbers in this assay, from the lowest: compounds 1, 2 and 3 (each within the scatter of the next).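

In this assay, for the compounds shown here, the exchange of 4-(trifluoromethyl)phenyl for 4-methoxyphenyl gives a 1.2-fold higher number from compound 2 to compound 3 (0.09 log units; within the scatter) and so offers the first direct reading of this change with the rest of the molecule held fixed. At this aromatic carbon, the two groups are not told apart, although they differ in heavy atoms and hydrogen-bond acceptors. Nothing measured here offers an explanation for this result. On these data alone, whether an amine, a carboxylic acid or a longer chain at this place would move the number beyond the scatter stays open. So does whether the same exchange reads alike in the setting of compound 1.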